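This account rests on a few compounds, and the source may have more. Where it says the series, first, only, none or still open, it means among the compounds named here.

The measured compounds:
- compound 1 `NC(=O)c1ccc(-c2cccnc2)cc1OC1CCNC1`: in an assay on cells for inhibition of MAP kinase-interacting serine/threonine-protein kinase 1 (Homo sapiens), read by mobility shift assay, with stated times of 10 min and 60 min, in the presence of a further agent that is not named here (a lower number here means a stronger inhibitor, a higher number a weaker inhibitor), compound 1 gives 1900 nM
- compound 2 `CC(C)Oc1cc(-c2cncc(-c3cnn(C4COC4)c3)c2)ccc1C(N)=O`: in this assay compound 2 gives 200 nM
- compound 3 `CC(C)Oc1cc(-c2cncc(-c3cnn(C4CCOC4)c3)c2)ccc1C(N)=O`: in this assay compound 3 gives 120 nM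

Among these three numbers compound 2 stands second highest. Its nearest neighbour is compound 3, and the step of a 1.7-fold lower number from compound 2 to compound 3 (0.22 log units; within the scatter) lies within the usual scatter; compound 1 is furthest away, with a clearly higher number than compound 2. Compound 4 `CC(C)Oc1cc(-c2cncc(-c3c[nH]nc3C3CC3)c2)ccc1C(N)=O` has not yet been measured. It differs from compound 2 in one place: 3-cyclopropyl-1H-pyrazol-4-yl in place of 1-(oxetan-3-yl)-1H-pyrazol-4-yl on an aromatic carbon. Among the measured compounds shown here, the only measured step that touches the same part of the molecule is a 1.7-fold lower number from compound 2 to compound 3 (0.22 log units; within the scatter), which exchanged one small oxygen-containing ring for another on the aromatic nitrogen and moved the number hardly at all. The new change is larger: the group on the aromatic nitrogen is gone, and a cyclopropyl is carried on the pyrazole instead. For the measured compounds named here, no measured pair shows a change of that kind, so the direction cannot be read from the data. The expected step of a 1.1-fold lower number from compound 2 to compound 4 (0.05 log units; within the scatter) is therefore set close to nothing beyond the scatter, with a wide range. Compound 4 is estimated at 180 nM, between 45 nM and 700 nM.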

Compound 4, half-maximal inhibitory concentration: 130 nM
Compound 4: middle estimate off by 1.4-fold (0.14 log units), on the high side; low and high end bracket the measured number.
By their numbers in this assay, from the lowest: compounds 3, 4 and 2 (each within the scatter of the next); then compound 1.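

In this assay the move to 3-cyclopropyl-1H-pyrazol-4-yl gives a 1.5-fold lower number from compound 2 to compound 4 (0.19 log units; within the scatter) and so stays within the usual scatter, even though this change is much larger than the earlier exchange of one oxygen-containing ring for another. For this pair, the number does not depend on an oxygen-containing ring on the aromatic nitrogen: the oxetan-3-yl group can be lost and the aromatic nitrogen left bearing a hydrogen, with the count going from 0 hydrogen-bond donors and 3 acceptors to 1 of each. No measurement shown here explains why the number holds. Two things changed at once, so the share of the lost oxetan-3-yl and that of the added cyclopropyl cannot be separated. On these data alone, whether an amine or a carboxylic acid on the pyrazole would give a similar number remains open.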